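The source may report more compounds than this note shows. Statements on the series, on what has been measured and on what is new or still open speak of the compounds shown alone.

Compound 2 `O=c1c(-c2nn[nH]n2)c[nH]c2c(F)cccc12` is the starting point. In a functional assay on the whole organism (strain Sprague-Dawley) for inhibition, with Rattus norvegicus as the target (a higher number here means that more compound is needed for the effect, a lower number that less compound is needed), compound 2 gives 0.625 mg/kg, the lowest of the two numbers shown. Its nearest neighbour is compound 3 `Cc1cc(F)c2[nH]cc(-c3nn[nH]n3)c(=O)c2c1`, which gives 2.5 mg/kg in this assay; a methyl in place of hydrogen on an aromatic carbon thus brings a 4.0-fold higher number from compound 2 to compound 3 (0.60 log units; beyond the scatter). Compound 1 `O=c1c(-c2nn[nH]n2)c[nH]c2c(F)ccc(F)c12` gives only a limit, > 0.156 mg/kg, in this assay. The removal of a fluoro from compound 1 therefore leaves a step that the limit leaves unreadable from compound 1 to compound 2.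

Compound 4 `COc1cccc2c(=O)c(-c3nn[nH]n3)c[nH]c12` has not yet been measured. It differs from compound 2 by methoxy in place of fluoro on an aromatic carbon. Neither measured step involves a methoxy, so the bearing of the known data is indirect: the step of a 4.0-fold higher number from compound 2 to compound 3 (0.60 log units; beyond the scatter) shows that adding a methyl to the shared core can raise the number by a modest amount, while the step that the limit leaves unreadable from compound 1 to compound 2 gives no readable size for removing a fluoro. The expectation for compound 4 is therefore a step of no more than modest size, most likely toward a higher number, estimated at a 2.0-fold higher number from compound 2 to compound 4 (0.30 log units; within the scatter). For compound 4 the estimated value in this assay is 1.25 mg/kg, with a range from 0.3 mg/kg to 5 mg/kg.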

Compound 4, minimum effective dose: 0.15 mg/kg
Compound 4: the middle estimate sits 8.3-fold (0.92 log units) above what was measured, outside the stated range (below it).
By their numbers in this assay, from the lowest: compound 4; then compound 2; then compound 3.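

Compounds 1, 2 and 3 all carry the fluoro on this aromatic carbon, so the methoxy is the first change shown at this place on the shared core, and in this assay it brings a 4.2-fold lower number from compound 2 to compound 4 (0.62 log units; beyond the scatter). Among these compounds, the fluoro is therefore not needed here for the effect: with methoxy in its place, less compound is needed, whereas the only earlier step that can be read, a methyl elsewhere on the same ring, went the other way, with a 4.0-fold higher number from compound 2 to compound 3 (0.60 log units; beyond the scatter). Nothing measured here says why the number falls with this change.

As far as these compounds go, a single swap cannot separate the oxygen from the added carbon, so it stays open whether a hydroxyl, an ethoxy or an amine on this same carbon would lower the number further, match the methoxy or lose the gain. It also stays open what the second fluoro of compound 1 adds, as that compound gives only a limit and its step cannot be read: the limit of > 0.156 mg/kg in this assay, at which 1 of the 4 values shown sits.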